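A few compounds are considered here, and "the series" means these few. Any claim that something is new, unique, unknown or untested is made for them only; others in the source may bear on it.

Compound 1 `CNCc1nnc(-c2ccccc2)s1` gives > 200 mg/kg in a functional assay on the whole organism with Mus musculus as the target (a higher number here means that more compound is needed for the effect, a lower number that less compound is needed), which is a limit. Compound 2 `NCc1nnc(-c2ccccc2-c2ccccc2)s1` gives 22 mg/kg in this assay. Compound 3 `NCCCc1nnc(-c2ccccc2-c2ccccc2)s1` gives > 200 mg/kg in this assay, again a limit.

Compound 3 thus stands at the limit of > 200 mg/kg in this assay, at which 2 of the 3 values shown sit, so its place among the numbers shown is known only as a limit. Compound 4 `CNCc1nnc(-c2ccccc2-c2ccccc2)s1` differs from compound 3 by methylamino in place of 2-aminoethyl on a saturated chain carbon bound to an aromatic carbon. Among the measured compounds shown here, one measured step bears on this change: an at least 9.0-fold higher number from compound 2 to compound 3 (0.95 log units; beyond the scatter), which runs the other way, from amino to 2-aminoethyl. Reversing it points to a lower number for compound 4, although compound 1 also carries methylamino and sits at the limit of > 200 mg/kg in this assay, at which 2 of the 3 values shown sit. Compound 4 is therefore expected to give 60 mg/kg, between 15 mg/kg and 200 mg/kg. That expectation means an at least 3.3-fold lower number from compound 3 to compound 4 (0.52 log units; beyond the scatter).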

Compound 4, dose for half-maximal effect: 20 mg/kg
Beside the measured number, compound 4's estimate is 3.0-fold (0.48 log units) above it, within the range that was stated.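

In this assay, an at least 10-fold lower number from compound 3 to compound 4 (1.00 log units; beyond the scatter), so at this saturated chain carbon bound to an aromatic carbon methylamino is far better tolerated than 2-aminoethyl, while a 1.1-fold lower number from compound 2 to compound 4 (0.04 log units; within the scatter) shows that methyl in place of hydrogen on the amine nitrogen makes no difference beyond the scatter. Methylamino alone does not suffice, however, as phenyl in place of hydrogen on an aromatic carbon gives an at least 10-fold lower number from compound 1 to compound 4 (1.00 log units; beyond the scatter). Two of these steps start from a limit: the limit of > 200 mg/kg in this assay, at which 2 of the 4 values shown sit.

Open remains how a dimethylamino group or a larger substituent on the amine nitrogen would read. Also open, going by these compounds, is whether a carboxylic acid in place of the amine would keep the effect.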